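The source may hold more compounds than are shown below. What is called first, only, known or untested is meant among the compounds shown, and "the series" means these compounds.

Compound 1 `OC(c1ccc(Cl)cc1)(c1cccnc1)c1ccccc1F` was tested in an ADME assay on L6 cells (Rattus norvegicus) for cytotoxicity, read by resazurin assay, with a stated time of 72 h; a higher number here means a weaker inhibitor, a lower number a stronger inhibitor. In this assay compound 1 gives > 100000 nM, which is a limit of the assay and not a number. Compound 2 `CC(C)Oc1ccc(C(O)(c2ccc(Cl)cc2)c2cccnc2)c(F)c1` carries the change (isopropoxy in place of hydrogen on an aromatic carbon). In this assay compound 2 gives 58200 nM. The step of an at least 1.7-fold lower number from compound 1 to compound 2 (0.23 log units; that floor lies within the scatter) rests on a limit at one end, a point made plain by the limit of > 100000 nM in this assay, at which 2 of the 3 values shown sit. Compound 3 `OC(c1ccc(Cl)cc1)(c1cccnc1)c1cncnc1` differs from compound 1 in its core, as described by pyrimidin-5-yl in place of 2-fluorophenyl on a saturated chain carbon bound to two aromatic carbons and an oxygen on a saturated carbon. In this assay compound 3 gives > 100000 nM, again a limit of the assay rather than a number. For that reason the step that the two limits leave unreadable from compound 1 to compound 3 cannot be read. Compound 4 `CC(C)Oc1ncc(C(O)(c2ccc(Cl)cc2)c2cccnc2)cn1` has not yet been measured. It differs from compound 3 by isopropoxy in place of hydrogen on an aromatic carbon, the same kind of change as that from compound 1 to compound 2, though here the place is on a six-membered aromatic ring with 2 nitrogen, between two ring nitrogen atoms, rather than on a ring of carbon only, meta to a fluoro group. Guided by the earlier step of an at least 1.7-fold lower number from compound 1 to compound 2 (0.23 log units; that floor lies within the scatter), the step from compound 3 to compound 4 is expected to be an at least 1.2-fold lower number from compound 3 to compound 4 (0.09 log units; that floor lies within the scatter). Compound 4 is therefore estimated at 80000 nM, with a likely range from 30000 nM to 200000 nM.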

Compound 4, half-maximal inhibitory concentration: > 100000 nM
Compound 4: a limit, no number (the forecaster's own chance of this, stated with the estimate: 50%); at least 1.2-fold (0.09 log units) between middle value and limit.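

In this assay compound 4 gives > 100000 nM, a limit of the assay and not a number. No new step can be read from compound 3 to compound 4, because both stand at a limit: the limit of > 100000 nM in this assay, at which 3 of the 4 values shown sit.

The compounds shown leave open whether isopropoxy changes the value at all on the ring it occupies in compound 4.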